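Shortening the hexyl chain on a hydroxamic acid series

A few compounds are considered here, and "the series" means these few. Any claim that something is new, unique, unknown or untested is made for them only; others in the source may bear on it.

Compound 1 `CCCCCCN(Cc1ccc(C(=O)NO)cc1)c1ncc(-c2ccc(C)cc2)s1` gives 4850 nM in a functional assay on HCT-116 cells (Homo sapiens) for antiproliferative activity, read by MTT assay, with a stated time of 48 h; a lower number here means a stronger inhibitor of growth, a higher number a weaker inhibitor of growth.
Compound 2 `Cc1ccc(OCCCN(Cc2ccc(C(=O)NO)cc2)c2ncc(-c3ccc(C)cc3)s2)cc1` gives 12600 nM.
Compound 3 `Cc1ccc(-c2cnc(N(CCCOc3ccccc3)Cc3ccc(C(=O)NO)cc3)s2)cc1` gives 4140 nM.

Among these three, compound 1 and compound 3 lie within the scatter of each other, as a 1.2-fold lower number from compound 1 to compound 3 (0.07 log units; within the scatter) shows, while compound 2 gives a higher number, with a 2.6-fold higher number from compound 1 to compound 2 (0.41 log units; beyond the scatter) beyond the scatter. Compound 4 `CCN(Cc1ccc(C(=O)NO)cc1)c1ncc(-c2ccc(C)cc2)s1` is obtained from compound 1 by hydrogen in place of butyl on a saturated chain carbon, two bonds along the chain from a nitrogen on an aromatic ring. For the measured compounds named here, no measured step shortens this chain: the two steps from compound 1 each exchange propyl for an aryloxy group, so they bear on compound 4 only loosely. A small shift is therefore expected, and compound 4 is estimated at 7000 nM (range 2500 nM to 20000 nM), which means an expected step of a 1.4-fold higher number from compound 1 to compound 4 (0.16 log units; within the scatter).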

Compound 4, concentration for 50% growth inhibition: 6870 nM
For compound 4 the middle estimate is 1.0-fold (0.01 log units) above the measured one, within the range that was stated.
By their numbers in this assay, from the lowest: compounds 3, 1, 4 and 2 (each within the scatter of the next, the first and the last beyond it).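

In this assay, hexyl to ethyl leaves compound 4 within the scatter of compound 1 (a 1.4-fold higher number from compound 1 to compound 4 (0.15 log units; within the scatter)), so the outer part of this chain can go without a step beyond the scatter. The ethyl chain also lies within the scatter of both aryloxy chains (a 1.7-fold higher number from compound 3 to compound 4 (0.22 log units; within the scatter); a 1.8-fold lower number from compound 2 to compound 4 (0.26 log units; within the scatter)), even though compound 2 and compound 3 are separated beyond it. No measurement shown here offers an explanation for these results. From the compounds shown here alone, it remains open whether a methyl, a longer chain or a terminal amine at this position would give a step beyond the scatter.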